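Swapping the sulfonamide substituent on the shared core

The source may hold more compounds than are shown below. What is called first, only, known or untested is meant among the compounds shown, and "the series" means these compounds.

Compound 1 `O=C([C@@H]1CCCN(S(=O)(=O)c2ccc(S(=O)(=O)N3CC[C@@H](O)C3)cc2)C1)N1CCC(F)(F)CC1` and compound 2 `CCN(CC)S(=O)(=O)c1ccc(S(=O)(=O)N2CCC[C@@H](C(=O)N3CCC(COC)CC3)C2)cc1` share a core in which a benzene ring bears two sulfonyl groups, one of them carrying a piperidine that ends in an amide. In a functional assay on MIA PaCa-2 cells (Homo sapiens) for inhibition, read by MTT assay, with a stated time of 7 days (a lower number here means a stronger inhibitor, a higher number a weaker inhibitor), compound 1 gives 210 nM, and compound 2 gives 250 nM; the two numbers sit within the scatter of each other, so neither can be called the stronger inhibitor. Compound 1 holds the lower of the two numbers shown. Compound 3 `CC(C)NS(=O)(=O)c1ccc(S(=O)(=O)N2CCC[C@@H](C(=O)N3CCC(F)(F)CC3)C2)cc1` differs from compound 1 in one place: isopropylamino in place of 3-hydroxypyrrolidin-1-yl on a sulfonyl sulfur. Among the compounds with values here, no measured pair shows what such a change does here. Because compound 2 carries a diethylamino group on the same sulfonyl sulfur and still gives 250 nM, the step is expected to stay within the scatter, with no clear direction. Compound 3 is therefore estimated at 250 nM, in a range from 100 nM to 650 nM, a step of a 1.2-fold higher number from compound 1 to compound 3 (0.08 log units; within the scatter).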

Compound 3, half-maximal inhibitory concentration: 350 nM
Beside the measured number, compound 3's estimate is 1.4-fold (0.15 log units) below it, within the range that was stated.
By their numbers in this assay, from the lowest: compounds 1, 2 and 3 (each within the scatter of the next).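

In this assay, within the data shown here, the change of 3-hydroxypyrrolidin-1-yl to isopropylamino on a sulfonyl sulfur gives a 1.7-fold higher number from compound 1 to compound 3 (0.22 log units; within the scatter), the first step that can be read at this position. It shows that the five-membered non-aromatic ring and its defined stereocentre can be exchanged here for a group with no ring, without a difference that stands clear of the scatter. No measurement is available that would explain this result.

The compounds shown do not tell whether a longer chain, or a chain ending in a carboxylic acid or an amine, on this sulfonyl sulfur would move the number beyond the scatter. Nor do they separate the loss of the ring from the loss of the hydroxy group, as the two leave together in this one step.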